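Methyl in place of fluoro on the pendant six-membered ring

A few compounds are considered here, and "the series" means these few. Any claim that something is new, unique, unknown or untested is made for them only; others in the source may bear on it.

Compound 1 `COc1ccc(/C(=C\c2ccc(F)cc2)c2cccc3ccccc23)c(OC)c1OC` and compound 2 `COc1ccc(/C(=C/c2ccc(F)cc2)c2cccc3ccccc23)c(OC)c1OC` carry the same atoms and differ only in the double-bond configuration as drawn. In a functional assay on HCT-116 cells (Homo sapiens) for inhibition, read by sulforhodamine B assay, with a stated time of 48 h (on this read-out higher numbers stand for weaker inhibition and lower numbers for stronger inhibition), compound 1 gives > 20000 nM, a limit of the assay rather than a number. Compound 2 gives > 20000 nM in this assay, again a limit. Compound 3 `COc1ccc(C(O)(Cc2ccccc2)c2cccc3ccccc23)c(OC)c1OC`, the hydroxy analogue, gives > 20000 nM in this assay, also a limit. Among the measured compounds shown here, the step that the two limits leave unreadable from compound 1 to compound 2 is therefore unreadable, as the limit of > 20000 nM in this assay, at which 3 of the 3 values shown sit, and the fact that compounds 1 and 2 differ only in the configuration as drawn together show: every value so far sits at the same limit, so compound 2 stands at that limit with no number behind it.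

Compound 4 `COc1ccc(/C(=C/c2ccc(C)cc2)c2cccc3ccccc23)c(OC)c1OC` differs from compound 2 by methyl in place of fluoro on an aromatic carbon. For the measured compounds named here, no measured step bears on a methyl-for-fluoro exchange, and the only step available, from compound 1 to compound 2, has no readable size. With all three values at the limit, compound 4 is expected to show no step beyond the scatter, a step that the limit leaves unreadable from compound 2 to compound 4, and most likely to return a limit as well. The estimate for compound 4 in this assay is 30000 nM, with a range from 5000 nM to 100000 nM.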

Compound 4, half-maximal inhibitory concentration: > 20000 nM
Compound 4 gave a limit, no number (the forecaster's own chance of this, stated with the estimate: 85%); the middle value does not contradict the limit.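

Compound 4 gives > 20000 nM in this assay, a limit of the assay. Among the compounds shown here, no step from compound 2 to compound 4 can be read, as both stand only as limits. The compounds shown leave open whether methyl in place of fluoro or the double-bond configuration changes inhibition at all.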